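Two More Fluorines on the Phenyl Ring of Compound 2

A few compounds are considered here, and "the series" means these few. Any claim that something is new, unique, unknown or untested is made for them only; others in the source may bear on it.

Compound 1 `COc1cc2ncnc(Nc3cccc(Cl)c3)c2cc1OCCCCC(=O)Nc1ccc(S(N)(=O)=O)cc1`, compound 2 `COc1cc2ncnc(Nc3cccc(F)c3)c2cc1OCCCCC(=O)Nc1ccc(S(N)(=O)=O)cc1` and compound 3 `COc1cc2ncnc(Nc3cccc(Cl)c3F)c2cc1OCCCCC(=O)Nc1ccc(S(N)(=O)=O)cc1` share one core and differ only in the phenyl group carried on a nitrogen on an aromatic ring. In a functional assay on NCI-H1975 cells (Homo sapiens) for antiproliferative activity, read by MTT assay, with a stated time of 72 h (a higher number here means a weaker inhibitor, a lower number a stronger inhibitor), compound 1 gives 33200 nM. Compound 3 gives 6930 nM in this assay. For compound 2 this assay reports only a limit, > 40000 nM. Compound 2 thus stands at the weak end of the numbers shown, at the limit of > 40000 nM in this assay, at which 1 of the 3 values shown sits.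

Compound 4 `COc1cc2ncnc(Nc3cc(F)c(F)c(F)c3)c2cc1OCCCCC(=O)Nc1ccc(S(N)(=O)=O)cc1` differs from compound 2 in one place: 3,4,5-trifluorophenyl in place of 3-fluorophenyl on a nitrogen on an aromatic ring. For the measured compounds named here, two measured steps bear on this. Putting fluoro in place of hydrogen gave a 4.8-fold lower number from compound 1 to compound 3 (0.68 log units; beyond the scatter), and exchanging the whole phenyl group gave an at least 5.7-fold lower number from compound 2 to compound 3 (0.76 log units; beyond the scatter). Both point towards a lower number when fluorine is added, although fluoro in place of chloro went the other way, with an at least 1.2-fold higher number from compound 1 to compound 2 (0.08 log units; that floor lies within the scatter). Compound 4 adds two fluorines, so a modest move towards a lower number is expected, while the limit on compound 2 leaves the starting point uncertain. The expected step is an at least 2.0-fold lower number from compound 2 to compound 4 (0.30 log units; that floor lies within the scatter). Compound 4 is therefore estimated at 20000 nM, with a range from 5000 nM to 60000 nM.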

Compound 4, half-maximal inhibitory concentration: 20000 nM
For compound 4 middle estimate and measured number coincide at the digits printed, within the range that was stated.
By their numbers in this assay, from the lowest: compound 3; then compounds 4 and 1 (each within the scatter of the next). At a limit, above all of these: compound 2.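

Compound 4 is the first compound here with fluorine as the only halogen on this phenyl ring to give a measured number rather than a limit in this assay, so that step can be read only as a floor, an at least 2.0-fold lower number from compound 2 to compound 4 (0.30 log units; that floor lies within the scatter), and it rests on this: the limit of > 40000 nM in this assay, at which 1 of the 4 values shown sits.

Chlorine on the ring is therefore not required for a measured number, yet replacing the 3-chloro-2-fluorophenyl group with the 3,4,5-trifluorophenyl group gives a 2.9-fold higher number from compound 3 to compound 4 (0.46 log units; beyond the scatter). Against the 3-chlorophenyl group, the same trifluorinated ring gives a 1.7-fold lower number from compound 1 to compound 4 (0.22 log units; within the scatter), so compound 1 and compound 4 cannot be told apart in this assay, and compound 3, with fewer fluorines than compound 4, shows that counting fluorines does not settle the outcome in this set.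

The compounds shown leave open how much each of the three fluorines contributes, a question that a 3,4-difluorophenyl or a 3-chloro-4-fluorophenyl group on the same nitrogen could address. They also leave open how the series would read with a trifluoromethyl or methoxy group on this ring, or with a longer chain in the linker.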